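The compounds below may be only part of what the source reports. "The series", "measured", "known", "first", "only" and "open" are said of these compounds alone.

In a toxicity assay on J774.A1 cells (Mus musculus) for cytotoxicity, read by SYBR Green assay, with a stated time of 1 h (a lower number here means that less compound is needed, a higher number that more compound is needed for the effect), three compounds built on one shared core have been measured: compound 1 (`CN(C)c1ccc2cc(-c3ccccc3)c(N)nc2c1`) gives 4900 nM, compound 2 (`CN(C)c1ccc2cc(-c3ccccc3Cl)c(N)nc2c1`) gives 2400 nM and compound 3 (`Cc1ccccc1-c1cc2ccc(N(C)C)cc2nc1N`) gives 6800 nM. Compound 2 holds the lowest of these numbers, and its gaps to both of the others lie beyond the scatter. Compound 4 (`CN(C)c1ccc2cc(-c3ccc(Cl)cc3Cl)c(N)nc2c1`) has not yet been measured. It departs from compound 2 in one place: chloro in place of hydrogen on an aromatic carbon. This is chloro in place of hydrogen on an aromatic carbon, meta to a chloro group and para to a large group.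

Among the measured compounds shown here, the nearest precedent is the same kind of exchange, a 2.0-fold lower number from compound 1 to compound 2 (0.31 log units; beyond the scatter). Methyl offers a contrast: a 1.4-fold higher number from compound 1 to compound 3 (0.14 log units; within the scatter), while a 2.8-fold higher number from compound 2 to compound 3 (0.45 log units; beyond the scatter). For the measured compounds named here, no measured step covers a second chloro or this exact place, so the evidence is thin. A further modest move toward a lower number in this assay is expected, though it may not clear the scatter. The expected change is a 1.6-fold lower number from compound 2 to compound 4 (0.20 log units; within the scatter). For compound 4, the estimated value is 1500 nM, with an expected range from 700 nM to 3300 nM.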

Compound 4, half-maximal effective concentration: 8700 nM
Compound 4: middle estimate off by 5.8-fold (0.76 log units), on the low side, outside the stated range (above it).
By their numbers in this assay, from the lowest: compound 2; then compounds 1, 3 and 4 (each within the scatter of the next).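

The second chloro did not repeat the first. In this assay, the earlier exchange of chloro for hydrogen lowered the number (a 2.0-fold lower number from compound 1 to compound 2 (0.31 log units; beyond the scatter)), whereas the same exchange meta to a chloro group and para to a large group raised it (a 3.6-fold higher number from compound 2 to compound 4 (0.56 log units; beyond the scatter)). The direction of this exchange therefore does not hold across the two steps shown, and the gain seen with compound 2 is lost once the further chloro enters, since compound 2 alone remains apart from the other compounds in this ordering. Nothing available explains this reversal, and no measurement bears on its cause.

The compounds shown leave open whether the rise belongs to this place on the ring or to the pairing of the two chloro groups, as no compound here carries a single chloro para to the large group. They also leave open whether a different group at this place, such as a methoxy group, an amine or a carboxylic acid, would raise the number in the same way or lower it.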